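A few compounds are considered here, and "the series" means these few. Any claim that something is new, unique, unknown or untested is made for them only; others in the source may bear on it.

Three compounds have been measured in a functional assay on MDA-MB-231 cells (Homo sapiens) for cytotoxicity, read by MTT assay, with a stated time of 72 h; a higher number here means a weaker inhibitor, a lower number a stronger inhibitor:

compound 1, `COc1ccc(Cn2nc(-c3ccccc3)c3cc(C(=N)Nc4ccccc4)nc(NC4CCCCC4)c32)cc1`, gives 3400 nM
compound 2, `COc1cc(Nc2nc(C(=N)Nc3cccc(C(F)(F)F)c3)cc3c(-c4ccccc4)n[nH]c23)cc(OC)c1OC`, gives 7600 nM
compound 3, `COc1ccc(Cn2nc(-c3ccccc3)c3cc(C(=N)Nc4ccccc4)nc(Nc4cc(OC)c(OC)c(OC)c4)c32)cc1`, gives 42100 nM

Compound 4, `N=C(Nc1cccc(C(F)(F)F)c1)c1cc2c(-c3ccccc3)n[nH]c2c(NC2CCCCC2)n1`, has not yet been measured. It is built from compound 2 by a single change, (cyclohexyl in place of 3,4,5-trimethoxyphenyl on a nitrogen on an aromatic ring). The same change, at the same kind of place, has been seen once before among these compounds: going from compound 3 to compound 1 it gave a 12-fold lower number from compound 3 to compound 1 (1.09 log units; beyond the scatter), a large move towards stronger inhibition. Both changes sit on a nitrogen on an aromatic ring whose other neighbours are aromatic carbon, so they are the same change on two different cores. How the core of compound 2 differs from the core of compound 3 is not broken down here; their values alone show that compound 2 sits between compound 1 and compound 3 in this assay.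

On the strength of that one earlier step, compound 4 is expected to inhibit more strongly than compound 2. The expected step is an 8.4-fold lower number from compound 2 to compound 4 (0.93 log units; beyond the scatter), taken somewhat smaller than the earlier one because it rests on a single example, a 12-fold lower number from compound 3 to compound 1 (1.09 log units; beyond the scatter), on a different core. For compound 4 the expected value in this assay is therefore 900 nM, with a likely range from 300 nM to 3000 nM.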

Compound 4, half-maximal inhibitory concentration: 24600 nM
Beside the measured number, compound 4's estimate is 27-fold (1.44 log units) below it, outside the stated range (above it).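

On the core of compound 2, putting cyclohexyl in place of 3,4,5-trimethoxyphenyl on the nitrogen gives weaker inhibition in this assay, with a 3.2-fold higher number from compound 2 to compound 4 (0.51 log units; beyond the scatter), so the gain seen on the other core does not carry over and the direction of the step is reversed. The two results of this one change clearly differ: the same change on two cores in this assay, a 12-fold lower number (1.09 log units; beyond the scatter) from compound 3 to compound 1 and a 3.2-fold higher number (0.51 log units; beyond the scatter) from compound 2 to compound 4, 40-fold (1.60 log units) apart, beyond the scatter of two such steps. This shows that, among these four compounds, the effect of the change depends on the core that carries it, and that a single step on one core is a poor guide to the same step on another; it does not show which difference between the two cores turns the effect around, as the cores differ in more than one place and no pair here separates those differences.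

A third core carrying the same two groups would show whether either direction is the more usual one, and a core differing from these in only one place would begin to narrow down the cause. Going by these compounds, it also remains open how a plain phenyl ring or a straight hexyl chain on the same nitrogen would behave on each of the two cores.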